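Phenyl in place of pyridine on the amide carbonyl

The compounds below may be only part of what the source reports. "The series", "measured", "known", "first", "only" and "open" are said of these compounds alone.

Measured so far:
compound 1 `O=C(NCN1CCC(c2cccc[n+]2[O-])CC1)c1cc(Cl)cc(Cl)c1` gives 64%
compound 2 `O=C(NCN1CCC(c2cccc[n+]2[O-])CC1)c1cnccc1Cl` gives 44%
compound 3 `O=C(NCN1CCC(c2cccc[n+]2[O-])CC1)c1ccccn1` gives 40%

All three compounds share one core and differ only in the aromatic ring attached to the carbonyl carbon. In a functional assay on HEK293 cells for agonist activity at D(4) dopamine receptor (Homo sapiens), read by FLIPR (a lower number here means a smaller maximal response, a higher number a larger maximal response), compound 1 gives 64%. Replacing its ring gave a number 20 percentage points lower from compound 1 to compound 2 (beyond the scatter) and a number 24 percentage points lower from compound 1 to compound 3 (beyond the scatter), while between the two pyridine-bearing compounds the change was a number 4 percentage points lower from compound 2 to compound 3 (within the scatter). Compound 3 thus stands lowest of the three numbers, though its gap to compound 2 lies within the scatter; only compound 1 is clearly above it.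

Compound 4 `O=C(NCN1CCC(c2cccc[n+]2[O-])CC1)c1ccccc1` is the next step: phenyl in place of pyridin-2-yl on a carbonyl carbon. Within the data shown here, no measured step has phenyl entering, so the bearing steps are those that swapped the ring on the carbonyl carbon. The one carbon-only ring measured, in compound 1, gave the highest value, but it also carried two chlorines, so only part of that difference may carry over. The expected step is a number 10 percentage points higher from compound 3 to compound 4 (within the scatter), a modest rise at most. Compound 4 is therefore estimated at 50%, with a range from 36% to 66%.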

Compound 4, largest response reached (reported as efficacy), in percent of the reference or control that the assay uses: 63%
For compound 4 the middle estimate is 13 percentage points below the measured one, within the range that was stated.
By their numbers in this assay, from the lowest: compounds 3 and 2 (each within the scatter of the next); then compounds 4 and 1 (each within the scatter of the next).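

In this assay the ring nitrogen alone makes a clear difference at this position: phenyl in place of pyridin-2-yl, with the same count of heavy atoms, gives a higher response (a number 23 percentage points higher from compound 3 to compound 4 (beyond the scatter)). Phenyl also stands clear of the chlorinated pyridine (a number 19 percentage points higher from compound 2 to compound 4 (beyond the scatter)), whereas the two chlorines of compound 1 make no difference beyond the scatter (a number 1 percentage points lower from compound 1 to compound 4 (within the scatter)). The high response of compound 1 therefore does not depend on its chlorines, and the two compounds with a carbon-only ring both stand above the two that carry a pyridine.

Nothing measured here explains why the carbon-only rings go with the larger response. On these data alone, it also remains open whether this holds for a phenyl ring bearing a single chlorine, a methoxy group or an amine.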